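A few compounds are considered here, and "the series" means these few. Any claim that something is new, unique, unknown or untested is made for them only; others in the source may bear on it.

Measured compounds in this series:
compound 1, `O=c1cc(/C=C/c2ccc([N+](=O)[O-])cc2)[nH]cc1O`, 4790 nM
compound 2, `COc1cc(/C=C/c2cc(=O)c(O)c[nH]2)cc(OC)c1`, 11400 nM
compound 3, `Cn1cc(O)c(=O)cc1/C=C/c1ccc([N+](=O)[O-])cc1`, 19200 nM

All three values come from a functional assay, with a stated time of 10 min; on this read-out lower numbers stand for stronger inhibition and higher numbers for weaker inhibition. Compound 1 and compound 3 share one core; compound 3 carries the change (methyl in place of hydrogen on an aromatic nitrogen), and the resulting step is a 4.0-fold higher number from compound 1 to compound 3 (0.60 log units; beyond the scatter). Compound 2 has a different core from compound 1, and the difference between the two cores is not broken down here. Compound 2 and compound 3 lie within the scatter of each other, while the gap from compound 2 to compound 1 is beyond the scatter.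

Compound 4, `COc1cc(/C=C/c2cc(=O)c(O)cn2C)cc(OC)c1`, is not yet measured. It differs from compound 2 by methyl in place of hydrogen on an aromatic nitrogen, which is the same change as from compound 1 to compound 3, at a place described in the same words. For the measured compounds named here, on the single earlier instance, a 4.0-fold higher number from compound 1 to compound 3 (0.60 log units; beyond the scatter), a step of similar direction is expected from compound 2 to compound 4, estimated as a 3.0-fold higher number from compound 2 to compound 4 (0.47 log units; beyond the scatter), with the caution that one pair on one core is a thin basis. For compound 4 in this assay the estimated value is 34000 nM, expected to fall between 15000 nM and 80000 nM.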

Compound 4, half-maximal inhibitory concentration: 3740 nM
The estimate for compound 4 lay 9.1-fold (0.96 log units) above the measured number; the whole stated range lies above it.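

In this assay, methyl in place of hydrogen on an aromatic nitrogen gives a 3.0-fold lower number from compound 2 to compound 4 (0.48 log units; beyond the scatter), so the change does not carry over from one core to the other with the same direction or size: the same change on two cores in this assay, a 4.0-fold higher number (0.60 log units; beyond the scatter) from compound 1 to compound 3 and a 3.0-fold lower number (0.48 log units; beyond the scatter) from compound 2 to compound 4, 12-fold (1.09 log units) apart, beyond the scatter of two such steps

With this difference, the earlier step cannot be applied to this series as a fixed increment, and the outcome of the change has to be read separately on each core. The two pairs do not show which part of the difference between the cores goes with the opposite steps, nor which direction would appear on a third core.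

The compounds shown carry only hydrogen or methyl on the aromatic nitrogen, so a longer chain at that place, such as ethyl, or a chain ending in an amine or a carboxylic acid, remains open. Also open, from the compounds shown here alone, is whether such groups would split the two cores in the same way as methyl does.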